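The source may hold more compounds than are shown below. What is called first, only, known or untested is meant among the compounds shown, and "the series" means these compounds.

The measured compounds in an assay on Prostate gland for inhibition of steroid 5-alpha-reductase (Rattus norvegicus); on this read-out lower numbers stand for stronger inhibition and higher numbers for weaker inhibition:
compound 1 `CCCC(CC)n1ccc2cc(/C(C)=C/C(=O)Nc3ccccc3OCCCC(=O)O)ccc21`: 9.3 nM
compound 2 `CCCCC(CCCC)n1ccc2cc(/C(C)=C/C(=O)Nc3ccccc3OCCCC(=O)O)ccc21`: 21 nM

On these two numbers compound 2 stands highest in this assay; its nearest neighbour is compound 1, which gives 9.3 nM and is thus the stronger inhibitor of the pair. Compound 3 `CCCCCC(c1ccccc1)n1ccc2cc(/C(C)=C/C(=O)Nc3ccccc3OCCCC(=O)O)ccc21` is the next compound, and it differs from compound 2 by 1-phenylhexyl in place of 1-butylpentyl on an aromatic nitrogen. Within the data shown here, only one measured step bears on this change: a 2.3-fold higher number from compound 1 to compound 2 (0.35 log units; beyond the scatter), a modest weakening when the branched chain on the aromatic nitrogen grew longer. Among the measured compounds shown here, compound 3 carries a still larger group there, but one that brings a six-membered aromatic ring rather than a longer chain, and no measured step shows what such a ring does at this place. A step of a 1.1-fold lower number from compound 2 to compound 3 (0.02 log units; within the scatter) is therefore expected, small and within the scatter around compound 2. Compound 3 is estimated at 20 nM in this assay, with a range from 6 nM to 70 nM.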

Compound 3, half-maximal inhibitory concentration: 25 nM
For compound 3 the middle estimate is 1.3-fold (0.10 log units) below the measured one; measured number inside the range.
By their numbers in this assay, from the lowest: compound 1; then compounds 2 and 3 (each within the scatter of the next).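

In this assay, the change to 1-phenylhexyl (a 1.2-fold higher number from compound 2 to compound 3 (0.08 log units; within the scatter)) shows that a six-membered aromatic ring of carbon only can stand on this aromatic nitrogen with no change in the number beyond the scatter, even though the entering group has 12 heavy atoms and the leaving group 9. Measured against 1-ethylbutyl, the same group gives a modest weakening (a 2.7-fold higher number from compound 1 to compound 3 (0.43 log units; beyond the scatter)), so compound 1 stays apart from both larger compounds and keeps the lowest number of the three. Nothing available explains these results.

From the compounds shown here alone, it remains open whether a shorter chain on the phenyl-bearing carbon, as in 1-phenylpropyl, would come closer to compound 1. Going by these compounds, the effect of a substituted ring, such as 4-fluorophenyl, or of a pyridine ring in place of the phenyl also remains open.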